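The compounds below may be only part of what the source reports. "The series", "measured", "known", "first", "only" and "open" are said of these compounds alone.

In a functional assay on PC-3 cells (Homo sapiens) for cytotoxicity (on this read-out lower numbers stand for stronger inhibition and higher numbers for weaker inhibition), compound 1 (`Cc1ccc(O)c(/C=N/c2nnc[nH]2)c1`) gives only a limit, > 30000 nM. Compound 2 (`Oc1ccccc1/C=N/n1cnnc1`) also gives only a limit, > 30000 nM. Compound 3 (`Oc1cccc(/C=N/n2cnnc2)c1O`) stands at a limit too, > 30000 nM, and so has no number of its own. All three compounds therefore sit at the limit of > 30000 nM in this assay, at which 3 of the 3 values shown sit.

Compound 4 (`Oc1cccc(/C=N/n2cnnc2)c1`) differs from compound 3 by hydrogen in place of hydroxy on an aromatic carbon. Among the measured compounds shown here, the one measured step that bears on this change is a step that the two limits leave unreadable from compound 2 to compound 3, and no size can be taken from it. No step beyond the scatter is therefore expected in this assay, and compound 4 is expected to stay near the limit. The estimated step is a step that the limit leaves unreadable from compound 3 to compound 4. For compound 4 the estimated value is 35000 nM, with an expected range of 10000 nM to 60000 nM.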

Compound 4, half-maximal inhibitory concentration: > 30000 nM
Compound 4 ended at the assay's limit; the forecaster's own chance of this, stated with the estimate: 85%; the middle value is on the limit's open side.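

Compound 3 and compound 4 both stop at a limit in this assay, so no step between them can be read: the limit of > 30000 nM in this assay, at which 4 of the 4 values shown sit.

The compounds shown leave open whether any change to this series gives a measurable value in this assay.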